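This account rests on a few compounds, and the source may have more. Where it says the series, first, only, none or still open, it means among the compounds named here.

Compound 1 `CO[C@@H]1[C@H](N(C)c2ncc(-c3c[nH]c4ccc(Cl)cc34)s2)C[C@H]2O[C@]1(C)n1c3ccccc3c3c4c(c5c6cc(Br)ccc6n2c5c31)C(=O)NC4`: 700 nM
Compound 2 `CO[C@@H]1[C@H](N(C)c2ncc(-c3c[nH]c4ccc(Br)cc34)s2)C[C@H]2O[C@]1(C)n1c3ccccc3c3c4c(c5c6cc(Br)ccc6n2c5c31)C(=O)NC4`: 390 nM

In a functional assay on MV4-11 cells (Homo sapiens) for antiproliferative activity, read by CellTiter-Glo, with a stated time of 72 h (on this read-out higher numbers stand for weaker inhibition and lower numbers for stronger inhibition), compound 1 gives 700 nM and compound 2 gives 390 nM. Compound 2 holds the lower of the two numbers, but the step of a 1.8-fold lower number from compound 1 to compound 2 (0.25 log units; within the scatter) lies within the scatter, so the two cannot be told apart. Compound 3 `COc1ccc2[nH]cc(-c3cnc(N(C)[C@@H]4C[C@H]5O[C@@](C)([C@@H]4OC)n4c6ccccc6c6c7c(c8c9cc(Br)ccc9n5c8c64)C(=O)NC7)s3)c2c1` differs from compound 2 by methoxy in place of bromo on an aromatic carbon. Within the data shown here, no measured step exchanges a halogen for a methoxy group; the single measured step swapped one halogen for another and stayed within the scatter. For compound 3 only a modest step is therefore expected, a 1.5-fold higher number from compound 2 to compound 3 (0.19 log units; within the scatter), with no firm direction. Compound 3 is estimated at 600 nM, between 150 nM and 2500 nM.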

Compound 3, half-maximal inhibitory concentration: 510 nM
Beside the measured number, compound 3's estimate is 1.2-fold (0.07 log units) above it; the range from low to high includes it.
By their numbers in this assay, from the lowest: compounds 2, 3 and 1 (each within the scatter of the next).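

At this aromatic carbon, methoxy cannot be told apart from either halogen in this assay: the data show a 1.3-fold higher number from compound 2 to compound 3 (0.12 log units; within the scatter) and a 1.4-fold lower number from compound 1 to compound 3 (0.14 log units; within the scatter). The earlier pair exchanged only one halogen for another, whereas this result extends the flat picture to a group that is not a halogen. Nothing measured here speaks to why these numbers stay so close. From the compounds shown here alone, whether an amine, a carboxylic acid or plain hydrogen at this carbon would leave the number within the scatter remains open, as does the outcome for a longer chain such as ethoxy.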